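Benzyl for Phenyl on Two Related Chloroacetyl Ureas

This account rests on a few compounds, and the source may have more. Where it says the series, first, only, none or still open, it means among the compounds named here.

Measured so far:
- compound 1 `O=C(CCl)NC(=O)Nc1ccc(Oc2ccccc2)cc1`: 3600 nM
- compound 2 `O=C(CCl)NC(=O)Nc1cccc(Oc2ccccc2)c1`: 5200 nM
- compound 3 `O=C(CCl)NC(=O)Nc1ccc(OCc2ccccc2)cc1`: 2600 nM

Of the compounds shown here, three have been tested in a functional assay on HT-29 cells (Homo sapiens) for inhibition, read by sulforhodamine B assay, with a stated time of 48 h; a lower number here means a stronger inhibitor of growth, a higher number a weaker inhibitor of growth. Compound 1 and compound 2 are built from the same atoms joined differently; the difference between their two cores is not broken down here. Compound 3 arises from compound 1 by the change (benzyl in place of phenyl on an oxygen on an aromatic ring), and in this assay that change gave a 1.4-fold lower number from compound 1 to compound 3 (0.14 log units; within the scatter). All three values lie within the usual scatter of one another, so none of them can be set apart from the others.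

Compound 4 `O=C(CCl)NC(=O)Nc1cccc(OCc2ccccc2)c1` has not yet been measured. Within the data shown here, it arises from compound 2 by benzyl in place of phenyl on an oxygen on an aromatic ring, which is the same change as the one from compound 1 to compound 3, made at a place described in the same words. Among the measured compounds shown here, the only guide to what it might do is that single earlier step. Because the step from compound 1 to compound 3 was a 1.4-fold lower number from compound 1 to compound 3 (0.14 log units; within the scatter), the step from compound 2 to compound 4 is expected to be of similar size, a 1.4-fold lower number from compound 2 to compound 4 (0.15 log units; within the scatter). On that basis compound 4 is estimated to give about 3700 nM in this assay, somewhere between 1800 nM and 8000 nM, though a single prior step is a thin footing and the outcome could well fall within the scatter of compound 2.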

Compound 4, concentration for 50% growth inhibition: 6500 nM
Estimate against measurement, compound 4: 1.8-fold (0.24 log units) below; the measured number falls inside the stated range.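

In this assay, putting benzyl in place of phenyl on an oxygen on an aromatic ring gave a 1.3-fold higher number from compound 2 to compound 4 (0.10 log units; within the scatter), so on this core the change cannot be told apart from no change at all. Set beside the earlier step on the other core, the new step does not differ from it: the same change on two cores in this assay, a 1.4-fold lower number (0.14 log units; within the scatter) from compound 1 to compound 3 and a 1.3-fold higher number (0.10 log units; within the scatter) from compound 2 to compound 4, 1.7-fold (0.24 log units) apart, within the scatter of two such steps This shows that the change behaves alike on these two cores in the limited sense that both steps are small, but it does not show a shared effect that carries over, since neither step can be distinguished from the ordinary spread of repeated measurements, and the printed directions of the two steps should not be read as a real reversal.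

Phenyl and benzyl are close relatives, so the compounds shown leave open whether a more different group on the same oxygen, such as a longer chain ending in a phenyl ring, or an amine or a carboxylic acid on that ring, would give a step large enough to compare between cores. They also leave open whether a change that clearly moves the number on one core would move it by a similar amount on the other.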